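Chloro to methyl on the shared core

This account rests on a few compounds, and the source may have more. Where it says the series, first, only, none or still open, it means among the compounds named here.

In a functional assay on KBVIN cells (Homo sapiens) for cytotoxicity, read by sulforhodamine B assay (a lower number here means a stronger inhibitor of growth, a higher number a weaker inhibitor of growth), compound 1 `Cc1ccc2c(c1)CCCN2c1nc(Cl)nc2ccccc12` gives 46 nM and compound 2 `COc1ccc2c(c1)C(=O)CCN2c1nc(Cl)nc2ccccc12` gives 33 nM. Going by the values given here, these two values lie within the scatter of each other, so compound 2 stands level with the only other measured compound. Compound 3 `COc1ccc2c(c1)C(=O)CCN2c1nc(C)nc2ccccc12` keeps the rest of compound 2 but has methyl in place of chloro on an aromatic carbon, between two ring nitrogen atoms (methyl in place of chloro on an aromatic carbon). Among the compounds with values here, both measured compounds carry chloro, so no measured pair shows what this exchange does in this assay. The working expectation is therefore a small shift toward a higher number, at or close to the edge of the usual scatter, and the estimated step is a 1.8-fold higher number from compound 2 to compound 3 (0.26 log units; within the scatter). For compound 3 the expected value is 60 nM, with an estimated range of 20 nM to 200 nM.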

Compound 3, concentration for 50% growth inhibition: 21 nM
For compound 3 the middle estimate is 2.9-fold (0.46 log units) above the measured one; the measured number falls inside the stated range.
By their numbers in this assay, from the lowest: compounds 3, 2 and 1 (each within the scatter of the next, the first and the last beyond it).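

In this assay, methyl in place of chloro on an aromatic carbon, between two ring nitrogen atoms, gives a 1.6-fold lower number from compound 2 to compound 3 (0.20 log units; within the scatter). Going by these compounds alone, this is the first direct reading at this position, and it shows that chloro is not required there for a number in this range, since compound 3 stands level with compound 2. Within the data shown here, nothing measured so far accounts for the two groups reading alike.

As far as these compounds go, the position has been read with only these two small groups, so it remains open whether an amine, a methoxy group or a longer chain in the same place would keep the number within the scatter. From the compounds shown here alone, the exchange has also been read on one background only, and whether it reads the same way with the other parts of compound 1 remains open.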